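From Methyl to Methoxy on a Weakly Cytotoxic Scaffold

The source may hold more compounds than are shown below. What is called first, only, known or untested is meant among the compounds shown, and "the series" means these compounds.

Among the compounds with values here, compound 2, `CC(=O)c1nn(-c2ccc(C)cc2)/c(=N/c2nc(-c3c(C)n(C)n(-c4ccccc4)c3=O)cs2)s1`, is the only compound here with a measured number: in a functional assay on A549 cells (Homo sapiens) for cytotoxicity, read by sulforhodamine B assay, with a stated time of 72 h (on this read-out lower numbers stand for stronger inhibition and higher numbers for weaker inhibition), compound 2 gives 20700 nM. Compound 1, `CC(=O)c1nn(-c2ccc(Cl)cc2)/c(=N/c2nc(-c3c(C)n(C)n(-c4ccccc4)c3=O)cs2)s1`, differs from it by a chloro in place of the methyl. In this assay compound 1 reaches only > 100000 nM, which is a limit of the assay rather than a number. The step between them is an at least 4.8-fold lower number from compound 1 to compound 2 (0.68 log units; beyond the scatter), and its size is open-ended because of the limit of > 100000 nM in this assay, at which 1 of the 2 values shown sits. Compound 3, `COc1ccc(-n2nc(C(C)=O)s/c2=N\c2nc(-c3c(C)n(C)n(-c4ccccc4)c3=O)cs2)cc1`, carries the change (methoxy in place of methyl on an aromatic carbon). No measured step swaps methyl for methoxy, so the one step shown is only a loose guide: it concerns the same position but a different pair of groups. The number for compound 3 is therefore expected to stay near that of its neighbour, a step of a 1.0-fold lower number from compound 2 to compound 3 (0.01 log units; within the scatter). In this assay compound 3 is expected to give 20000 nM, within 7000 nM to 60000 nM.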

Compound 3, half-maximal inhibitory concentration: 26500 nM
Beside the measured number, compound 3's estimate is 1.3-fold (0.12 log units) below it, and the stated range covers the measured number.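

In this assay, methoxy and methyl cannot be told apart at this position on the aromatic ring (a 1.3-fold higher number from compound 2 to compound 3 (0.11 log units; within the scatter)), so adding the oxygen of the 4-methoxyphenyl group brings no change beyond the scatter. Methoxy also parts from chloro in the same direction as methyl did (an at least 3.7-fold lower number from compound 1 to compound 3 (0.57 log units; beyond the scatter)), which makes compound 1 the one that stands apart among these three compounds. As far as these compounds go, the size of that step stays open-ended because compound 1 sits at a limit of the assay rather than at a number: the limit of > 100000 nM in this assay, at which 1 of the 3 values shown sits.

The compounds shown leave open whether an amine, a carboxylic acid or a longer chain such as ethoxy at this position would fall with methyl and methoxy or with chloro. They also leave open whether fluoro would follow chloro.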